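A few compounds are considered here, and "the series" means these few. Any claim that something is new, unique, unknown or untested is made for them only; others in the source may bear on it.

Measured compounds:
- compound 1 `CCN1CCN(C[C@H]2CN(c3ccc(-n4cc(-c5ccccn5)cn4)c(F)c3)C(=O)O2)CC1`: 99 ug/mL
- compound 2 `CCC(=O)NC[C@H]1CN(c2ccc(-n3cc(-c4ccccn4)cn3)c(F)c2)C(=O)O1`: 204 ug/mL

Both numbers come from an ADME assay on L02 cells (Homo sapiens) for cytotoxicity, read by MTT assay, with a stated time of 48 h; on this read-out higher numbers stand for weaker inhibition and lower numbers for stronger inhibition. Within this pair compound 2 gives the higher number, 204 ug/mL, and compound 1 the lower, 99 ug/mL; the one step between them, a 2.1-fold higher number from compound 1 to compound 2 (0.31 log units; beyond the scatter), carries the change from the basic ring substituent to the open-chain amide.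

Compound 3 `O=CNC[C@H]1CN(c2ccc(-n3cc(-c4ccccn4)cn3)c(F)c2)C(=O)O1` is the next member. Against compound 2 the difference is hydrogen in place of ethyl on a carbonyl carbon; the carbonyl and the amide nitrogen stay, only the ethyl branch on the carbonyl carbon is lost. Among the compounds with values here, no measured step touches the carbonyl side of this amide, so the only step on record, from compound 1 to compound 2, changes a different part of the chain and is at best a loose guide to scale. With the amide kept and the shared core untouched, the expected step for compound 3 in this assay is a 1.1-fold lower number from compound 2 to compound 3 (0.03 log units; within the scatter), that is, no step beyond the scatter in either direction. Compound 3 is accordingly expected to give 190 ug/mL, within a range of 90 ug/mL to 400 ug/mL.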

Compound 3, half-maximal inhibitory concentration: > 400 ug/mL
Compound 3 ended at the assay's limit; the forecaster's own chance of this, stated with the estimate: 25%; middle value at least 2.1-fold (0.32 log units) from the limit.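

In this assay compound 3 gives > 400 ug/mL, which is a limit of the assay and not a number: the limit of > 400 ug/mL in this assay, at which 1 of the 3 values shown sits. Read as a floor, hydrogen in place of ethyl on a carbonyl carbon gives an at least 1.9-fold higher number from compound 2 to compound 3 (0.29 log units; that floor lies within the scatter), so this change, the only one shown on the carbonyl side of the amide, cannot yet be called a step beyond the scatter, although the true step may be larger. Formylamino in place of 4-ethylpiperazin-1-yl gives an at least 4.0-fold higher number from compound 1 to compound 3 (0.60 log units; beyond the scatter), and together with a 2.1-fold higher number from compound 1 to compound 2 (0.31 log units; beyond the scatter) this places both open-chain amides on the higher-number side of compound 1, with no compound shown going against that.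

Where compound 3 truly lies remains open, and with only hydrogen and ethyl on this carbonyl carbon, nothing shows how a methyl group, a longer chain or a methoxy group there would read in this assay. Going by these compounds, whether a simple open-chain amine on the same chain carbon would read with compound 1 or with the amides also stays open.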